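Swapping a Pyrimidine for a Furan in a Non-Toxic Series

A few compounds are considered here, and "the series" means these few. Any claim that something is new, unique, unknown or untested is made for them only; others in the source may bear on it.

Compound 1 `CCOC(=O)CCCCCOc1cccc(CN(C(=O)c2ccc(-c3cccc4ccccc34)cc2)C(C)C)c1`: in an ADME assay on HEK293 cells (Homo sapiens) for cytotoxicity, read by CellTiter-Glo and resazurin assay, with a stated time of 72 h (a higher number here means that more compound is needed for the effect, a lower number that less compound is needed), compound 1 reaches only the limit > 26000 nM.
Compound 2 `CCOC(=O)CCCCCOc1cccc(CN(C(=O)c2ccc(-c3ccncc3)cc2)C(C)C)c1`: in this assay compound 2 reaches only the limit > 26000 nM.
Compound 3 `CCOC(=O)CCCCCOc1cccc(CN(C(=O)c2ccc(-c3cnc(OC)nc3OC)cc2)C(C)C)c1`: in this assay compound 3 reaches only the limit > 26000 nM.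

Within the data shown here, compound 3 therefore stands at the top of the measured range, where the assay stops reporting a number, a point shared by every value so far (the limit of > 26000 nM in this assay, at which 3 of the 3 values shown sit). The next compound, compound 4 `CCOC(=O)CCCCCOc1cccc(CN(C(=O)c2ccc(-c3ccoc3)cc2)C(C)C)c1`, differs from compound 3 in one place: furan-3-yl in place of 2,4-dimethoxypyrimidin-5-yl on an aromatic carbon.

Among the measured compounds shown here, three measured steps bear on such an aryl exchange. The step that the two limits leave unreadable from compound 1 to compound 2, the step that the two limits leave unreadable from compound 1 to compound 3 and the step that the two limits leave unreadable from compound 2 to compound 3 all run between limits, so their sizes cannot be read. For the measured compounds named here, no measured step therefore gives a direction, and the expectation for this assay is a step that the limit leaves unreadable from compound 3 to compound 4, again most likely ending at a limit rather than a number. Compound 4 is estimated at 40000 nM, with a range from 20000 nM to 100000 nM.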

Compound 4, half-maximal effective concentration: > 26000 nM
Compound 4: a limit, no number; the forecaster's own chance of this, stated with the estimate: 85%; the middle value does not contradict the limit.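

Compound 4 gives > 26000 nM, a limit and not a number, so the steps to it from compound 1, compound 2 and compound 3 cannot be read. The compounds shown leave open what concentration of any of them reaches the half-maximal effect in this assay, and whether exchanging these groups changes it.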